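Saturated chain on the aromatic nitrogen: propyl to but-3-en-1-yl

This account rests on a few compounds, and the source may have more. Where it says the series, first, only, none or still open, it means among the compounds named here.

Compound 1 `COc1cc(Cc2nc3c(N)nc(F)nc3n2CC2CCCO2)cc(OC)c1OC` — in a functional assay on MCF7 cells (Homo sapiens) for antiproliferative activity (a higher number here means a weaker inhibitor, a lower number a stronger inhibitor), compound 1 gives 22900 nM
Compound 2 `C#CCCn1c(Cc2cc(OC)c(OC)c(OC)c2)nc2c(N)nc(F)nc21` — in this assay compound 2 gives 25100 nM
Compound 3 `CCCn1c(Cc2cc(OC)c(OC)c(OC)c2)nc2c(N)nc(F)nc21` — in this assay compound 3 gives 25100 nM

Compound 3 stands level with compound 2, the two together giving the highest numbers of the three, and its nearest neighbour is compound 2 with no change at the digits printed from compound 2 to compound 3 (within the scatter); its furthest is compound 1, from which the step is a 1.1-fold higher number from compound 1 to compound 3 (0.04 log units; within the scatter). All three numbers lie within the usual scatter of one another.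

Compound 4 `C=CCCn1c(Cc2cc(OC)c(OC)c(OC)c2)nc2c(N)nc(F)nc21` differs from compound 3 only on the chain bound to the aromatic nitrogen: vinyl in place of methyl on a saturated chain carbon, two bonds along the chain from an aromatic nitrogen.

Among the compounds with values here, the steps that bear on this change are those that alter the same chain. From compound 1 to compound 2 the step was a 1.1-fold higher number from compound 1 to compound 2 (0.04 log units; within the scatter), from compound 1 to compound 3 it was a 1.1-fold higher number from compound 1 to compound 3 (0.04 log units; within the scatter), and from compound 2 to compound 3, where an ethynyl gave way to a methyl at the very position now concerned, it was no change at the digits printed from compound 2 to compound 3 (within the scatter). None of these changes to the chain moved the number beyond the scatter, so for compound 4 no step beyond the scatter is expected in this assay in either direction, and the estimated step is a 1.0-fold lower number from compound 3 to compound 4 (0.00 log units; within the scatter).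

Compound 4 is therefore expected to give about 25000 nM in this assay, with a range from 12000 nM to 50000 nM.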

Compound 4, half-maximal inhibitory concentration: 33100 nM
Estimate against measurement, compound 4: 1.3-fold (0.12 log units) below; the measured number falls inside the stated range.
By their numbers in this assay, from the lowest: compounds 1, 2, 3 and 4 (each within the scatter of the next).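

Vinyl now stands at this carbon alongside methyl and ethynyl, and in this assay it gives a 1.3-fold higher number from compound 3 to compound 4 (0.12 log units; within the scatter) and a 1.3-fold higher number from compound 2 to compound 4 (0.12 log units; within the scatter), so the three groups at the chain's end are not told apart by this read-out. Measured against oxolan-2-yl on the saturated chain carbon bound to the aromatic nitrogen, allyl gives a 1.4-fold higher number from compound 1 to compound 4 (0.16 log units; within the scatter), which adds a fourth chain to the set without any step leaving the scatter, and so, across these compounds, neither the open chains nor the ring-bearing chain stands apart. Nothing measured here offers a reason for these numbers, or for the absence of a clear difference among them.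

The compounds shown leave open whether this chain can move the number beyond the scatter at all, since all of them carry uncharged hydrocarbon or ether groups there. An amine or a carboxylic acid at the end of the chain, or a much longer chain, would test this, and the compounds here give no indication of what such a group would do in this assay.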